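This account rests on a few compounds, and the source may have more. Where it says the series, first, only, none or still open, it means among the compounds named here.

Compound 1 `COc1cc(C[C@@H](O)[C@@H]2C[C@@H](O)[C@@H](c3ccc(O)c(OC)c3)[C@H](c3ccc(O)c(OC)c3)O2)ccc1O` gives > 50000 nM in a functional assay on RAW264.7 cells (Mus musculus) for inhibition, read by Griess assay, with stated times of 1 h and 24 h (a lower number here means a stronger inhibitor, a higher number a weaker inhibitor), as a limit and not a number, so its position can only be given as a limit. Compound 2 `COc1cc(C[C@@H](O)[C@@H]2C[C@@H](O)[C@@H](c3cc(OC)c(O)c(OC)c3)[C@H](c3ccc(O)c(OC)c3)O2)ccc1O` gives a measured 23600 nM in this assay and carries one added methoxy. Among the measured compounds shown here, that substitution, methoxy in place of hydrogen on an aromatic carbon, accounts for the only measured step, an at least 2.1-fold lower number from compound 1 to compound 2 (0.32 log units; beyond the scatter) and this lies beyond the scatter.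

The next comparison is compound 3 `COc1cc(C[C@@H](O)[C@H]2C[C@H](O)[C@@H](c3ccc(O)c(OC)c3)[C@H](c3ccc(O)c(OC)c3)O2)ccc1O` against compound 1, where the two compounds have the same atoms and bonds and differ only in configuration as drawn: 2 of 5 stereo elements differ; a stereocentre at a saturated ring carbon is drawn S in compound 1 and R in compound 3; a stereocentre at a saturated ring carbon is drawn R in compound 1 and S in compound 3 and no group leaves or enters. The measured step bears on this only loosely, since it is a substitution and no change of configuration has yet been measured in this series. For the measured compounds named here, it shows only that one structural change took compound 2 to a measured number. Going by the values given here, no large step is therefore expected in this assay and the direction is uncertain, with a slight lean towards a lower number.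

The expected result is an at least 1.2-fold lower number from compound 1 to compound 3 (0.09 log units; that floor lies within the scatter) with a return to the limit remaining quite possible. The estimate for compound 3 is 40000 nM within an expected range of 15000 nM to 90000 nM in this series.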

Compound 3, half-maximal inhibitory concentration: > 50000 nM
Compound 3 was reported as a limit (the forecaster's own chance of this, stated with the estimate: 50%); at least 1.2-fold (0.09 log units) between middle value and limit.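

In this assay compound 3 gives > 50000 nM as a limit and not a number. Among the compounds shown here, compound 1 also stands at a limit, so no step between compound 1 and compound 3 can be read: the limit of > 50000 nM in this assay, at which 2 of the 3 values shown sit. The compounds shown leave open whether this change of configuration alters the inhibition at all.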